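Replacing the sulfonamide nitrogen substituent of compound 2

A few compounds are considered here, and "the series" means these few. Any claim that something is new, unique, unknown or untested is made for them only; others in the source may bear on it.

In a physicochemical assay for solubility, read by spectrophotometry, measured as kinetic solubility, at pH 8, tested at 500 uM (on this read-out lower numbers stand for lower solubility and higher numbers for higher solubility), compound 1 (`Cn1ccc2ccc(-c3cc(Nc4ccccc4S(=O)(=O)Nc4cncnc4)cc4nccnc34)cc21`) gives 254 ug/mL and compound 2 (`CN1CCCC(NS(=O)(=O)c2ccccc2Nc2cc(-c3ccc4ccn(C)c4c3)c3nccnc3c2)C1`) gives 9 ug/mL as the lower of the two numbers. Compound 3 (`Cn1ccc2ccc(-c3cc(Nc4ccccc4S(=O)(=O)NCC4CCOCC4)cc4nccnc34)cc21`) carries (oxan-4-yl)methyl in place of 1-methylpiperidin-3-yl on a sulfonamide nitrogen. Among the compounds with values here, only one measured step touches this place, a 28-fold lower number from compound 1 to compound 2 (1.45 log units; beyond the scatter), which is large and beyond the scatter. That step removed pyrimidin-5-yl, a group not involved in the present change, so it gives no direct measure of this exchange. Both groups here hold one six-membered non-aromatic ring, and no step beyond the scatter is expected in this assay. The expected change is a 1.5-fold lower number from compound 2 to compound 3 (0.18 log units; within the scatter), with a slightly lower number only a tentative call. For compound 3 the estimated value is 6 ug/mL (1.5 ug/mL to 25 ug/mL).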

Compound 3, solubility: 2 ug/mL
Compound 3: the middle estimate sits 3.0-fold (0.48 log units) above what was measured, and the stated range covers the measured number.
By their numbers in this assay, from the lowest: compound 3; then compound 2; then compound 1.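

In this assay, (oxan-4-yl)methyl in place of 1-methylpiperidin-3-yl on a sulfonamide nitrogen gives a 4.5-fold lower number from compound 2 to compound 3 (0.65 log units; beyond the scatter), so this position shows a step beyond the scatter even between two groups with the same heavy-atom and hydrogen-bond counts. Against pyrimidin-5-yl, the same group gives a 130-fold lower number from compound 1 to compound 3 (2.10 log units; beyond the scatter), which places both groups with a non-aromatic ring well under compound 1, with compound 3 the lowest of the three. Nothing measured here explains the step between compound 2 and compound 3.

The exchange alters the ring hetero atom and adds the methyl link of (oxan-4-yl)methyl together, and the compounds shown do not separate the two. Also open, going by these compounds, is where an open-chain amine or a carboxylic acid on this nitrogen would fall relative to compound 1.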